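This account rests on a few compounds, and the source may have more. Where it says the series, first, only, none or still open, it means among the compounds named here.

Measured compounds:
- compound 1, `CSc1nc(NCCCc2ccccc2)c2ccccc2n1`. In an ADME assay on BEAS-2B cells (Homo sapiens) for cytotoxicity, read by MTT assay, with a stated time of 72 h (a higher number here means a weaker inhibitor of growth, a lower number a stronger inhibitor of growth), compound 1 gives > 100000 nM, which is a limit of the assay rather than a number.
- compound 2, `CCCCCSc1nc(NCc2ccc([Se]C)cc2)c2ccccc2n1`. Compound 2 gives > 100000 nM, again a limit of the assay.
- compound 3, `CSc1nc(NCc2ccc([Se]C)cc2)c2ccccc2n1`. Compound 3 gives > 100000 nM, also a limit of the assay.

Compound 3 therefore stands at the edge of what this assay can report, and the two further values shown sit at the same edge: the limit of > 100000 nM in this assay, at which 3 of the 3 values shown sit. Among the compounds with values here, the only measured step between neighbours, a step that the two limits leave unreadable from compound 2 to compound 3, is one that the two limits leave unreadable, so it gives no size at all.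

Compound 4, `CSc1nc(NCc2ccccc2)c2ccccc2n1`, differs from compound 3 by a hydrogen atom in place of a group of 2 heavy atoms (1 carbon, 1 selenium; no ring), on an aromatic carbon. No measured step covers this change, and the one step shown cannot be read, so there is no ground to expect any step beyond the scatter in this assay. The expected step from compound 3 to compound 4 is a step that the limit leaves unreadable from compound 3 to compound 4. Compound 4 is estimated at 150000 nM, with a range from 60000 nM to 400000 nM, most likely reported only as a limit.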

Compound 4, concentration for total growth inhibition: 88200 nM
The estimate for compound 4 lay 1.7-fold (0.23 log units) above the measured number, and the stated range covers the measured number.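

With a hydrogen atom in place of the group of 2 heavy atoms (1 carbon, 1 selenium) on the aromatic carbon, compound 4 gives 88200 nM in this assay, the first value shown here that is a true number rather than a limit. The change at this position can now be given a minimum size, an at least 1.1-fold lower number from compound 3 to compound 4 (0.05 log units; that floor lies within the scatter), so the data show no change beyond the usual scatter, though they do not rule out a larger one. The true size of the step stays unknown, and compound 3 offers only a limit: the limit of > 100000 nM in this assay, at which 3 of the 4 values shown sit.

The compounds shown leave open how large this step really is and whether the selenium atom itself matters. They also leave open what a methoxy group, a chlorine atom or an amine on the same aromatic carbon would give in this assay.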